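This account rests on a few compounds, and the source may have more. Where it says the series, first, only, none or still open, it means among the compounds named here.

Compound 1 `COc1cccc(/C=C2\CCC/C(=C\c3ccccc3Br)C2=O)c1OC`: 12100 nM
Compound 2 `COc1ccccc1/C=C1\CCC/C(=C\c2cccc(OC)c2OC)C1=O`: > 20000 nM
Compound 3 `COc1ccc(/C=C2\CCC/C(=C\c3cccc(Cl)c3)C2=O)cc1OC`: 5100 nM

The three measured compounds share one core and differ only in the groups carried on the two aryl rings. In a functional assay on SW-620 cells (Homo sapiens) for cytotoxicity, read by MTT assay, with a stated time of 72 h (on this read-out lower numbers stand for stronger inhibition and higher numbers for weaker inhibition), compound 1 gives 12100 nM. Compound 2 reaches only a limit of the assay, > 20000 nM, so no number is known for it. Compound 3 gives 5100 nM in this assay, the lowest of the two numbers obtained; the nearest number is that of compound 1, higher by a gap beyond the scatter.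

Compound 4 `COc1ccc(/C=C2\CCC/C(=C\c3cccc(Cl)c3Cl)C2=O)cc1OC` has not yet been measured. Its difference from compound 3 is chloro in place of hydrogen on an aromatic carbon. Within the data shown here, only one measured step exists, an at least 1.6-fold higher number from compound 1 to compound 2 (0.21 log units; that floor lies within the scatter), and it concerns a different change, a methoxy in place of bromo. Its floor lies within the scatter, and it rests on a limit (the limit of > 20000 nM in this assay, at which 1 of the 3 values shown sits). Among the measured compounds shown here, no measured step therefore speaks to adding a chloro group, and the step from compound 3 to compound 4 is expected to stay within the scatter: a 1.0-fold lower number from compound 3 to compound 4 (0.01 log units; within the scatter). Compound 4 is thus estimated at 5000 nM, with a range from 2000 nM to 13000 nM.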

Compound 4, half-maximal inhibitory concentration: 10800 nM
For compound 4 the middle estimate is 2.2-fold (0.33 log units) below the measured one; the range from low to high includes it.
By their numbers in this assay, from the lowest: compound 3; then compounds 4 and 1 (each within the scatter of the next). At a limit, above all of these: compound 2.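

Changing 3-chlorophenyl to 2,3-dichlorophenyl, with the other aryl ring left as it was, weakens the result in this assay, and the change is a 2.1-fold higher number from compound 3 to compound 4 (0.33 log units; beyond the scatter). Among these compounds, this is the first step that stands beyond the scatter, and the first to show what adding a group to an aromatic carbon does: here a second chloro group, ortho to the first, brings a modest loss rather than a gain. Nothing shown here explains why this one added atom raises the number.

Going by these compounds, whether a fluoro group, a methyl group or an amine on this same carbon would raise the number as well remains open. So does whether the same step would appear with a different set of groups on the other aryl ring.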